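Sulfonyl aryl swap from compound 3 to compound 4

The compounds below may be only part of what the source reports. "The series", "measured", "known", "first", "only" and "open" are said of these compounds alone.

Values measured in a functional assay on LNCaP cells (Homo sapiens) for antiproliferative activity, read by propidium iodide staining, with a stated time of 96 h (a higher number here means a weaker inhibitor, a lower number a stronger inhibitor), are as follows.
- compound 1 `CC(O)(COc1cccc(OC(F)(F)F)c1)C(=O)Nc1cccc(S(F)(F)(F)(F)F)c1` gives 15200 nM
- compound 2 `CC(O)(CS(=O)(=O)c1ccc(S(F)(F)(F)(F)F)cc1)C(=O)Nc1ccc(S(F)(F)(F)(F)F)cc1` gives 29200 nM
- compound 3 `CC(O)(CS(=O)(=O)c1ccc(C(F)(F)F)cc1)C(=O)Nc1ccc(S(F)(F)(F)(F)F)cc1` gives 20700 nM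

Compound 3 (20700 nM) lies within the scatter of both compound 1 and compound 2. The next entry is compound 4 `CC(O)(CS(=O)(=O)c1ccccc1OC(F)(F)F)C(=O)Nc1ccc(S(F)(F)(F)(F)F)cc1` and the change is 2-(trifluoromethoxy)phenyl in place of 4-(trifluoromethyl)phenyl on a sulfonyl sulfur with 2-(trifluoromethoxy)phenyl in place of 4-(trifluoromethyl)phenyl on a sulfonyl sulfur.

Among the compounds with values here, only one measured step alters the aromatic group on the sulfonyl side. This is a 1.4-fold lower number from compound 2 to compound 3 (0.15 log units; within the scatter) and it stays within the scatter. Compound 1 (15200 nM) also carries a trifluoromethoxy group, but it differs from compound 3 in more than one place and is only a loose guide. Within the data shown here, no measurement yet shows a trifluoromethoxy group on a sulfonyl-bound ring, so the data leave this particular swap untested.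

Resting on compound 3 (20700 nM) and on that single small step, no shift beyond the scatter is expected, and no direction is favoured. The expected step is a 1.0-fold lower number from compound 3 to compound 4 (0.01 log units; within the scatter) in this assay as a working figure. The estimated value for compound 4 is 20000 nM (expected range 8000 nM to 45000 nM).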

Compound 4, half-maximal inhibitory concentration: 12700 nM
Estimate against measurement, compound 4: 1.6-fold (0.20 log units) above; the measured number falls inside the stated range.
By their numbers in this assay, from the lowest: compounds 4, 1, 3 and 2 (each within the scatter of the next, the first and the last beyond it).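

In this assay the sulfonyl sulfur takes 2-(trifluoromethoxy)phenyl in place of 4-(trifluoromethyl)phenyl with a 1.6-fold lower number from compound 3 to compound 4 (0.21 log units; within the scatter) as the outcome, so a swap that alters both the ring substituent and its printed ring place, and brings in a hydrogen-bond acceptor, leaves the reading unresolved from that of compound 3. This entry also gives the first gap beyond the scatter among groups on the sulfonyl sulfur: compound 4 gives 12700 nM and compound 2 gives 29200 nM with the rest of the structure shared, although each sits within the scatter of its neighbour in the ranking. No supporting measurement is available to account for where these numbers fall.

Within the data shown here, the single swap does not separate the trifluoromethoxy group from its ring place, so neither can be credited on its own with the reading of compound 4. Also open is how this position responds to an amine or a carboxylic acid on the ring in place of the fluorinated groups, as every sulfonyl-bound ring shown carries a fluorinated substituent.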